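The compounds below may be only part of what the source reports. "The series", "measured", "known", "first", "only" and "open" are said of these compounds alone.

Compound 2 `CC#C[C@@H](Cc1nnn[nH]1)c1ccc(OCc2ccc3sc(F)c(-c4ccc(OCCOC)cc4C)c3c2)cc1` stands lowest of the two numbers in a functional assay on cells for agonist activity at Free fatty acid receptor 1 (Homo sapiens), read by FLIPR and calcium flux (a lower number here means that less compound is needed, a higher number that more compound is needed for the effect), where compound 2 gives 18 nM. Its nearest neighbour is compound 1 `CC#C[C@@H](Cc1nnn[nH]1)c1ccc(OCc2ccc3sc(C)c(-c4ccc(OCCOC)cc4C)c3c2)cc1`, which in this assay gives 47 nM; the step of a 2.6-fold lower number from compound 1 to compound 2 (0.42 log units; beyond the scatter) came from a fluoro in place of methyl on an aromatic carbon. Compound 3 `CC#C[C@@H](Cc1nnn[nH]1)c1ccc(OCc2ccc3sc(C(F)(F)F)c(-c4ccc(OCCOC)cc4C)c3c2)cc1` carries the change (trifluoromethyl in place of fluoro on an aromatic carbon). Within the data shown here, only that one step bears on it, and it points away from the methyl, so nothing shows how the larger trifluoromethyl would fare. The expected step of a 2.2-fold higher number from compound 2 to compound 3 (0.35 log units; beyond the scatter) is a modest rise, and compound 3 is estimated at 40 nM in this assay, within 12 nM to 130 nM.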

Compound 3, half-maximal effective concentration: 13 nM
The estimate for compound 3 lay 3.1-fold (0.49 log units) above the measured number; the range from low to high includes it.
By their numbers in this assay, from the lowest: compounds 3 and 2 (each within the scatter of the next); then compound 1.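

In this assay, trifluoromethyl in place of fluoro on the aromatic carbon next to the ring sulfur gives a 1.4-fold lower number from compound 2 to compound 3 (0.14 log units; within the scatter), so the two groups cannot be told apart here, despite four heavy atoms replacing one. Trifluoromethyl in place of methyl gives a 3.6-fold lower number from compound 1 to compound 3 (0.56 log units; beyond the scatter), so compound 1 remains apart from both compound 2 and compound 3 at this position. Nothing available explains this result. As far as these compounds go, whether a chlorine, a nitrile or a methoxy group here would match fluoro and trifluoromethyl or match methyl remains open.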